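Acyl chain shortened to hydroxyacetyl on trimethoxyanilide

A few compounds are considered here, and "the series" means these few. Any claim that something is new, unique, unknown or untested is made for them only; others in the source may bear on it.

Compound 1 `COc1ccc(CN(C(=O)CCCCCl)c2cc(OC)c(OC)c(OC)c2)cc1O` carries the 5-chloropentanoyl amide and stands at the strong end of the series: in a functional assay on KYSE-450 cells (Homo sapiens) for inhibition, read by MTT assay, with a stated time of 48 h (a higher number here means a weaker inhibitor, a lower number a stronger inhibitor), compound 1 gives 770 nM, the lowest of the two numbers read in full. The nearest measured neighbour, compound 3 `COc1ccc(CNc2cc(OC)c(OC)c(OC)c2)cc1Cl`, gives 47800 nM in this assay, a gap well beyond the scatter. Compound 2 `COc1cc(NCc2ccccc2)cc(OC)c1OC` is reported only as the limit of > 80000 nM in this assay, at which 1 of the 3 values shown sits. In this assay compound 2 sits at > 80000 nM, which is a limit of the assay and not a number. Within the data shown here, no pair of measured compounds differs in a single place, so no measured step is available for the change below.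

Compound 4 `COc1ccc(CN(C(=O)CO)c2cc(OC)c(OC)c(OC)c2)cc1O` keeps the core and the amide of compound 1 and differs in one place: hydroxy in place of 3-chloropropyl on a saturated chain carbon bound to a carbonyl carbon. The 4-chlorobutyl becomes hydroxymethyl, so the acyl part shrinks to (hydroxymethyl)carbonyl.

The step from compound 1 to compound 4 is expected to be a loss, beyond the scatter, in this assay, written as a 4.5-fold higher number from compound 1 to compound 4 (0.66 log units; beyond the scatter). Compound 4 is therefore estimated at 3500 nM, with a plausible range from 700 nM to 18000 nM.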

Compound 4, half-maximal inhibitory concentration: 370 nM
Compound 4: the middle estimate sits 9.5-fold (0.98 log units) above what was measured, outside the stated range (below it).
By their numbers in this assay, from the lowest: compound 4; then compound 1; then compound 3. At a limit, above all of these: compound 2.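

Comparing the two amides in this assay, hydroxy in place of 3-chloropropyl on a saturated chain carbon bound to a carbonyl carbon gives a 2.1-fold lower number from compound 1 to compound 4 (0.32 log units; beyond the scatter) and so a modest gain instead of a loss. The 4-chlorobutyl group and its chlorine are therefore not required for activity in this series, and the much smaller (hydroxymethyl)carbonyl amide serves at least as well on the shared core. This position accepts a large change in the acyl part, with both a chlorine-bearing chain and a short hydroxy-bearing one giving sub-micromolar numbers on this core.

The step changes chain length and terminal group together, so the two cannot be told apart here, and nothing shown bears on the cause of the step. A plain acetyl amide would separate the effect of the shorter chain from that of the hydroxy, a 5-hydroxypentanoyl chain would test the hydroxy at the original length, and an aminoacetyl or carboxylic acid group at the same place would show how far the position extends to other end groups.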